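The compounds below may be only part of what the source reports. "The series", "measured", "known", "first", "only" and "open" are said of these compounds alone.

In a functional assay on RPMI-8226 cells (Homo sapiens) for antiproliferative activity, read by radiometric assay, with a stated time of 72 h (on this read-out lower numbers stand for stronger inhibition and higher numbers for weaker inhibition), three compounds that share a core and differ only in the group on one nitrogen have been measured. Compound 1 `Cc1cc(F)ccc1Nc1ncnc2cc(NC(=O)CCCCCCC(=O)NO)sc12` gives 1950 nM, compound 2 `O=C(CCCCCCC(=O)Nc1cc2ncnc(Nc3ccc(Cl)cc3F)c2s1)NO` gives 1900 nM and compound 3 `Cc1ccc(F)c(Nc2ncnc3cc(NC(=O)CCCCCCC(=O)NO)sc23)c1` gives 1060 nM. Compound 3 stands level with the other two, since a 1.8-fold lower number from compound 1 to compound 3 (0.26 log units; within the scatter) and a 1.8-fold lower number from compound 2 to compound 3 (0.25 log units; within the scatter) both lie within the scatter. The remaining pair behaves the same way, with a 1.0-fold lower number from compound 1 to compound 2 (0.01 log units; within the scatter).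

Compound 4 `CCc1cccc(Nc2ncnc3cc(NC(=O)CCCCCCC(=O)NO)sc23)c1` differs from compound 3 in one place, on a nitrogen on an aromatic ring: 3-ethylphenyl in place of 2-fluoro-5-methylphenyl (3-ethylphenyl in place of 2-fluoro-5-methylphenyl on a nitrogen on an aromatic ring). All three measured steps bear on this change, as each exchanges the group at that same place, and none moves the number beyond the scatter. They are imperfect guides, however. For the measured compounds named here, every measured compound keeps fluorine on this ring, so the data hold no direct precedent for its loss or for an ethyl group.

No shift beyond the scatter is therefore expected in this assay. The estimated step is a 1.2-fold higher number from compound 3 to compound 4 (0.09 log units; within the scatter). For compound 4 the expected value is 1300 nM, with an estimated range of 600 nM to 2800 nM.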

Compound 4, half-maximal inhibitory concentration: 1570 nM
For compound 4 the middle estimate is 1.2-fold (0.08 log units) below the measured one, within the range that was stated.
By their numbers in this assay, from the lowest: compounds 3, 4, 2 and 1 (each within the scatter of the next).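

For the compounds shown here, compound 4 is the first in this set whose group on the nitrogen carries no halogen, and the first with an ethyl group there. In this assay, the exchange of 2-fluoro-5-methylphenyl for the all-carbon 3-ethylphenyl stays within the scatter (a 1.5-fold higher number from compound 3 to compound 4 (0.17 log units; within the scatter)), and so do the comparisons with the other two groups (a 1.2-fold lower number from compound 2 to compound 4 (0.08 log units; within the scatter)) and (a 1.2-fold lower number from compound 1 to compound 4 (0.09 log units; within the scatter)), so among these four compounds neither fluorine on this ring nor a halogen of any kind is needed to stay level. No measurement in hand accounts for this flat behaviour or says what the groups contribute at this position.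

Going by these compounds, all four groups are substituted phenyl rings made up of carbon and halogen only, so it remains open whether a phenyl bearing an amine or a carboxylic acid, or a saturated ring such as cyclohexyl, would stay level with them. The four compounds also share the same amide chain on the core, which leaves open whether a shorter or longer chain would change the picture at this nitrogen.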